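Swapping Cyclopropyl for a Longer Chain on the Amine

The source may report more compounds than this note shows. Statements on the series, on what has been measured and on what is new or still open speak of the compounds shown alone.

Four related compounds share one core and differ in the group attached to an amine nitrogen. Compound 1 `COc1ccc(CCCNCc2c(OC)cc(Oc3ccc(Nc4ccccc4)cc3)cc2OC)cc1` gives 3230 nM in a functional assay on HCT-116 cells (Homo sapiens) for inhibition, read by MTT assay, with a stated time of 72 h; on this read-out lower numbers stand for stronger inhibition and higher numbers for weaker inhibition. Compound 2 `COc1cc(Oc2cccc(Nc3ccccc3)c2)cc(OC)c1CNCc1ccc(Cl)cc1` gives 3310 nM in this assay. For compound 3 `COc1cc(Oc2cccc(Nc3ccccc3)c2)cc(OC)c1CNC1CC1` the result in this assay is only a limit, > 20000 nM, so it sits at the weak end of the numbers shown. Going by the values given here, the one measured step that bears on it, an at least 6.0-fold higher number from compound 2 to compound 3 (0.78 log units; beyond the scatter), shows that shrinking the group on the amine nitrogen to cyclopropyl costs activity. Compound 4 `COc1ccc(CCCNCc2c(OC)cc(Oc3cccc(Nc4ccccc4)c3)cc2OC)cc1` reverses that move: 3-(4-methoxyphenyl)propyl in place of cyclopropyl on an amine nitrogen. A step back toward stronger inhibition is expected, an at least 5.7-fold lower number from compound 3 to compound 4 (0.75 log units; beyond the scatter), because compound 1 with the same chain gives 3230 nM. Compound 4 is therefore estimated at 3500 nM, ranging from 1500 nM to 9000 nM.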

Compound 4, half-maximal inhibitory concentration: 2850 nM
Estimate against measurement, compound 4: 1.2-fold (0.09 log units) above; measured number inside the range.
By their numbers in this assay, from the lowest: compounds 4, 1 and 2 (each within the scatter of the next). At a limit, above all of these: compound 3.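

With 3-(4-methoxyphenyl)propyl on the amine nitrogen, activity in this assay returns to the level lost with cyclopropyl (an at least 7.0-fold lower number from compound 3 to compound 4 (0.84 log units; beyond the scatter)). This change also shows that two different groups on this nitrogen, each carrying an aromatic ring, cannot be told apart here (a 1.2-fold lower number from compound 2 to compound 4 (0.06 log units; within the scatter)). The first step has only a minimum size, as compound 3 stands at a limit of the assay: the limit of > 20000 nM in this assay, at which 1 of the 4 values shown sits.

Going by these compounds, whether the aromatic ring or the chain length matters more remains open. A plain propyl chain or an unsubstituted benzyl group would help separate the two.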